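A few compounds are considered here, and "the series" means these few. Any claim that something is new, unique, unknown or untested is made for them only; others in the source may bear on it.

Compound 3 `ClCc1cccc(Cn2cnc3nc(Cl)nc(Cl)c32)c1` and compound 2 `ClCc1ccc(Cn2cnc3nc(Cl)nc(Cl)c32)cc1` are built from the same atoms joined differently; the difference between their two cores is not broken down here. In a functional assay on A498 cells (Homo sapiens) for cytotoxicity, read by sulforhodamine B assay, with a stated time of 48 h (a higher number here means a weaker inhibitor of growth, a lower number a stronger inhibitor of growth), compound 3 gives 2810 nM, while compound 2 gives 23400 nM. Compound 1 `ClCc1cccc(Cn2cnc3ncnc(Cl)c32)c1` is derived from compound 3 by hydrogen in place of chloro on an aromatic carbon, and in this assay compound 1 gives 36300 nM, so the step of a 13-fold higher number from compound 3 to compound 1 (1.11 log units; beyond the scatter) is large. Compound 4 `ClCc1ccc(Cn2cnc3ncnc(Cl)c32)cc1` has not yet been measured in this assay; it is derived from compound 2 by hydrogen in place of chloro on an aromatic carbon, which is the same change at a place described in the same words. Because compound 2 already gives 23400 nM and the earlier step was a 13-fold higher number from compound 3 to compound 1 (1.11 log units; beyond the scatter), compound 4 is expected to show a step of about a 6.4-fold higher number from compound 2 to compound 4 (0.81 log units; beyond the scatter), matching the size seen once before. This rests on a single observed instance of the change, so the expectation is loose, and a number this high may fall outside what the assay reports. Compound 4 is estimated at 150000 nM, within a range from 40000 nM to 500000 nM.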

Compound 4, concentration for total growth inhibition: 3380 nM
The estimate for compound 4 lay 44-fold (1.65 log units) above the measured number; measured number below the stated range.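

In this assay, hydrogen in place of chloro on the aromatic carbon between two ring nitrogen atoms gave a 6.9-fold lower number from compound 2 to compound 4 (0.84 log units; beyond the scatter), whereas the same replacement on the other core had given a 13-fold higher number from compound 3 to compound 1 (1.11 log units; beyond the scatter). The two steps run in opposite directions, and the gap between them lies beyond the scatter: the same change on two cores in this assay, a 13-fold higher number (1.11 log units; beyond the scatter) from compound 3 to compound 1 and a 6.9-fold lower number (0.84 log units; beyond the scatter) from compound 2 to compound 4, 89-fold (1.95 log units) apart, beyond the scatter of two such steps This shows that, across these two pairs, the result of the change did not carry from one core to the other, so one pair could not be used to predict the other; it does not show why the direction reverses, and two pairs give no rule for any further core.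

The compounds shown have only chloro or hydrogen on that carbon, so it remains open whether an amine or a methoxy group there would show the same dependence on the core. As far as these compounds go, it also remains open whether a longer chain in place of the chloromethyl group would keep the reversal seen here.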